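This account rests on a few compounds, and the source may have more. Where it says the series, first, only, none or still open, it means among the compounds named here.

Working notes on the series.

Compound 1 `CCCCSc1nsnc1C1CN2CCC1CC2` in a functional assay on the whole organism for inhibition, with Rattus norvegicus as the target (a lower number here means that less compound is needed, a higher number that more compound is needed for the effect), gives 0.1 mg/kg. Compound 2 `CCCCSc1nsnc1C1CN2CCC[C@@H]1C2` in this assay gives > 3 mg/kg, which is a limit of the assay and not a number. Compound 3 `CCCCSc1nsnc1[C@@H]1CN2CCC[C@@H]1C2` in this assay gives > 3 mg/kg, again a limit of the assay. Among the measured compounds shown here, compound 2 therefore stands without a readable number, and the only measured step that touches it, a step that the two limits leave unreadable from compound 2 to compound 3, cannot be sized because the limit of > 3 mg/kg in this assay, at which 2 of the 3 values shown sit, caps both ends; the pair differs solely in the fact that one of compounds 2 and 3 is drawn with a defined configuration and the other without, at the place where they differ. Compound 4 `CCCCSc1nsnc1C1CN2CCC[C@H]1C2` has not yet been measured in this assay. The change from compound 2 to compound 4 is the two compounds have the same atoms and bonds; at least one stereo element is drawn with a configuration in one of them and without one in the other: 1 of 3 stereo elements differ; a stereocentre at a saturated ring carbon is drawn S in compound 2 and R in compound 4. For the measured compounds named here, no measured step resolves a switch of configuration at that centre, so neither size nor direction can be read from the measured compounds. Compound 4 is expected near 2 mg/kg, with a range from 0.3 mg/kg to 10 mg/kg. That estimate for compound 4 implies an expected step of an at least 1.5-fold lower number from compound 2 to compound 4 (0.17 log units; that floor lies within the scatter), and a limit is the most likely outcome.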

Compound 4, dose for half-maximal effect: 0.007 mg/kg
For compound 4 the middle estimate is 290-fold (2.46 log units) above the measured one, outside the stated range (below it).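

At this saturated ring carbon, configuration alone carries a large effect in this assay, since with atoms and bonds unchanged the switch from S to R gives an at least 420-fold lower number from compound 2 to compound 4 (2.63 log units; beyond the scatter) on the side of the limit. The second step, an at least 420-fold lower number from compound 3 to compound 4 (2.63 log units; beyond the scatter), points the same way, although two stereo elements differ in that pair. The earlier compounds shown here ended at limits of the assay and gave neither a direction nor a size at this centre, whereas R at this centre now gives a readable value and the step out of each limit has a floor.

The step between the two limits cannot be read, so the stereocentre that separates those compounds stays unresolved. On these data alone, how a longer chain or an amine on the shared core would behave with the R configuration also stays open.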